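The source may report more compounds than this note shows. Statements on the series, on what has been measured and on what is new or still open speak of the compounds shown alone.

Working notes on the sulfonamide series carrying the shared core of compound 1 `O=c1[nH]cc(S(=O)(=O)Nc2ccccc2-c2cn(-c3ccccc3)nn2)c(=O)[nH]1`. In an ADME assay on GES1 cells (Homo sapiens) for cytotoxicity, read by MTT assay, with a stated time of 24 h (on this read-out lower numbers stand for higher toxicity in this test and higher numbers for lower toxicity in this test), compound 1 gives a limit of the assay at > 100000 nM. Compound 2 `O=c1[nH]cc(S(=O)(=O)Nc2ccccc2-c2cn(-c3ccccc3F)nn2)c(=O)[nH]1` carries a fluoro in place of hydrogen on an aromatic carbon; in this assay compound 2 gives a limit as well, at > 100000 nM. Compound 3 `O=c1[nH]cc(S(=O)(=O)Nc2ccccc2-c2cn(-c3cccc(Cl)c3)nn2)c(=O)[nH]1` carries a chloro on an aromatic carbon; in this assay compound 3 likewise gives only a limit, at > 100000 nM. Compound 3 thus stands at the same limit as the rest, described by the limit of > 100000 nM in this assay, at which 3 of the 3 values shown sit. The steps a step that the two limits leave unreadable from compound 1 to compound 2, a step that the two limits leave unreadable from compound 1 to compound 3 and a step that the two limits leave unreadable from compound 2 to compound 3 are all hidden by that limit.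

Compound 4 `O=c1[nH]cc(S(=O)(=O)Nc2ccccc2-c2cn(-c3ccc(Cl)cc3)nn2)c(=O)[nH]1` is the next member, differing from compound 3 by 4-chlorophenyl in place of 3-chlorophenyl on an aromatic nitrogen. Among the compounds with values here, no measured step in this assay speaks to this change, since every step so far is unreadable; the only guidance is that three ring-substituent variations all remained at the limit. Compound 4 is therefore expected to show no readable step, a number no higher from compound 3 to compound 4 (the limit leaves the size open), and most likely to sit at the limit again. Compound 4 is estimated at 100000 nM, within 50000 nM to 200000 nM.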

Compound 4, half-maximal cytotoxic concentration: 26700 nM
Compound 4: the middle estimate sits 3.7-fold (0.57 log units) above what was measured, outside the stated range (below it).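

In this assay, exchanging 3-chlorophenyl for 4-chlorophenyl on the same aromatic nitrogen gives an at least 3.7-fold lower number from compound 3 to compound 4 (0.57 log units; beyond the scatter), so with the same atoms, joined differently, the place of the chloro alone separates the two compounds. The other two comparisons read the same way, with an at least 3.7-fold lower number from compound 2 to compound 4 (0.57 log units; beyond the scatter) and an at least 3.7-fold lower number from compound 1 to compound 4 (0.57 log units; beyond the scatter), so a chloro on this group is not enough in itself, as the 3-chlorophenyl of compound 3 stays at the limit. Compound 4 is the only one shown with a readable number, and the others remain at a limit of the assay: the limit of > 100000 nM in this assay, at which 3 of the 4 values shown sit.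

The steps among compound 1, compound 2 and compound 3 cannot be read. Going by these compounds, whether the lower number belongs to chloro specifically or to any group at that place stays open, and 4-fluorophenyl, 4-methoxyphenyl or 4-aminophenyl on the same nitrogen would bear on that.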